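Swapping the Ester Acyl Group: From Compound 1 to Compound 4

The compounds below may be only part of what the source reports. "The series", "measured", "known", "first", "only" and "open" are said of these compounds alone.

Compound 1 `O=C(OC1(C(=O)Nc2ccc([N+](=O)[O-])cc2)CCCCC1)c1ccc(Cl)cc1` carries a 4-chlorophenyl group on a carbonyl carbon whose other neighbour is an oxygen next to a carbonyl group. In a functional assay on HepG2 cells (Homo sapiens) for inhibition, read by MTT assay, with a stated time of 72 h (a higher number here means a weaker inhibitor, a lower number a stronger inhibitor), compound 1 gives 21.8 nM, the lowest number among the three measured compounds. Compound 3 `O=COC1(C(=O)Nc2ccc([N+](=O)[O-])cc2)CCCCC1`, with hydrogen at that carbonyl carbon, gives 34.1 nM in this assay; the step of a 1.6-fold higher number from compound 1 to compound 3 (0.19 log units; within the scatter) stays within the scatter. Compound 2 `O=C(/C=C/c1ccccc1)OC1(C(=O)Nc2ccc([N+](=O)[O-])cc2)CCCCC1`, with 2-phenylethenyl there, gives 52.9 nM; the step of a 2.4-fold higher number from compound 1 to compound 2 (0.38 log units; beyond the scatter) goes beyond the scatter, while a 1.6-fold lower number from compound 2 to compound 3 (0.19 log units; within the scatter) again lies within it.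

Compound 4 `CC(=O)Oc1ccccc1C(=O)OC1(C(=O)Nc2ccc([N+](=O)[O-])cc2)CCCCC1` has not yet been measured. It differs from compound 1 in one place: 2-acetoxyphenyl in place of 4-chlorophenyl on a carbonyl carbon. Both measured steps bear on this change, since each also replaces the 4-chlorophenyl group on the same carbonyl carbon: a 2.4-fold higher number from compound 1 to compound 2 (0.38 log units; beyond the scatter) and a 1.6-fold higher number from compound 1 to compound 3 (0.19 log units; within the scatter). Because a 2.4-fold higher number from compound 1 to compound 2 (0.38 log units; beyond the scatter) and a 1.6-fold higher number from compound 1 to compound 3 (0.19 log units; within the scatter) were both small, the 2-acetoxyphenyl group is expected to behave alike, with no more than a modest rise in the number. Compound 4 is therefore expected to give about 30 nM in this assay, within a range from 12 nM to 75 nM. The expected step of a 1.4-fold higher number from compound 1 to compound 4 (0.14 log units; within the scatter) would not clearly exceed the scatter.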

Compound 4, half-maximal inhibitory concentration: 17.7 nM
For compound 4 the middle estimate is 1.7-fold (0.23 log units) above the measured one, and the stated range covers the measured number.
By their numbers in this assay, from the lowest: compounds 4, 1, 3 and 2 (each within the scatter of the next, the first and the last beyond it).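

In this assay, replacing 4-chlorophenyl with 2-acetoxyphenyl on this carbonyl carbon brings in 10 heavy atoms and 2 hydrogen-bond acceptors where 7 heavy atoms and 0 acceptors leave, yet a 1.2-fold lower number from compound 1 to compound 4 (0.09 log units; within the scatter) stays within the scatter, as does a 1.9-fold lower number from compound 3 to compound 4 (0.28 log units; within the scatter), so hydrogen, 4-chlorophenyl and 2-acetoxyphenyl cannot be told apart at this position. Going by these compounds alone, the only separation the new compound adds is a 3.0-fold lower number from compound 2 to compound 4 (0.48 log units; beyond the scatter), which lies beyond the scatter and is modest; even so, compound 2 is not cleanly set apart from the rest, as its step to compound 3 stays within the scatter. No measurement shown here explains why this position accepts groups of such different size with so little change in the number.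

From the compounds shown here alone, it remains open whether the acetoxy part of the new group contributes anything, a question that plain phenyl or 2-hydroxyphenyl at this carbonyl carbon could address. Also open, going by these compounds, is whether an amine, a carboxylic acid or a longer alkyl chain there would keep the number this low, and how changes elsewhere on the shared core would compare.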